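Compound 4: methyl in place of bromo

A few compounds are considered here, and "the series" means these few. Any claim that something is new, unique, unknown or untested is made for them only; others in the source may bear on it.

Values in an ADME assay on microsomes from liver (Rattus norvegicus) for metabolic stability; a higher number here means that the compound lasts longer, a lower number that the compound disappears faster:
- compound 1 `Nc1nc(NCCNc2ncc(-c3ncc[nH]3)c(-c3ccc(C(F)(F)F)cc3)n2)ccc1[N+](=O)[O-]`: > 0.5 h
- compound 2 `Nc1nc(NCCNc2ncc(-c3ncc[nH]3)c(-c3cc(F)c(Cl)cc3Cl)n2)ccc1[N+](=O)[O-]`: > 0.5 h
- compound 3 `Nc1nc(NCCNc2ncc(-c3ncc[nH]3)c(-c3ccc(Cl)cc3Br)n2)ccc1[N+](=O)[O-]`: > 0.5 h

Compound 3 gives > 0.5 h in this assay, which is a limit and not a number. The same holds across the set, with the limit of > 0.5 h in this assay, at which 3 of the 3 values shown sit.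

Compound 4 `Cc1cc(Cl)ccc1-c1nc(NCCNc2ccc([N+](=O)[O-])c(N)n2)ncc1-c1ncc[nH]1` differs from compound 3 in one place: methyl in place of bromo on an aromatic carbon. This is methyl in place of bromo on an aromatic carbon, ortho to a large group and meta to a chloro group.

For the measured compounds named here, three measured steps bear on this change, all exchanges of the same aryl group: a step that the two limits leave unreadable from compound 1 to compound 3, a step that the two limits leave unreadable from compound 2 to compound 3 and a step that the two limits leave unreadable from compound 1 to compound 2. Going by the values given here, none has a readable size, and no measured pair isolates bromo against methyl. No direction is therefore expected, and no step beyond the usual scatter. The expected step is a step that the limit leaves unreadable from compound 3 to compound 4. For compound 4 the estimate is 0.7 h, with an expected range of 0.35 h to 1.5 h.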

Compound 4, half-life: > 0.5 h
Compound 4: a limit, no number; the forecaster's own chance of this, stated with the estimate: 70%; the middle value does not contradict the limit.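

No new step can be read between compound 4 and compound 1, compound 2 or compound 3, as all four values in this assay are limits and not numbers: the limit of > 0.5 h in this assay, at which 4 of the 4 values shown sit.

The compounds shown leave open the actual half-lives of all four compounds, and whether methyl in place of bromo shifts the value in this assay at all.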